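Adding Chloro to the Fluorophenyl Ring of Compound 3

This account rests on a few compounds, and the source may have more. Where it says the series, first, only, none or still open, it means among the compounds named here.

Three compounds have been measured in a functional assay on U-87MG ATCC cells for antiproliferative activity against U-87 MG (Homo sapiens), read by MTT assay, with a stated time of 72 h; a higher number here means a weaker inhibitor, a lower number a stronger inhibitor:
Compound 1, `O=C(Nc1ccc(Oc2ccnc3[nH]ccc23)cc1)c1cc2cccnc2n(-c2ccc(F)cc2)c1=O`, gives 1360 nM.
Compound 2, `COc1ccc(-n2c(=O)c(C(=O)Nc3ccc(Oc4ccnc5[nH]ccc45)cc3)cc3cccnc32)cc1`, gives 2350 nM.
Compound 3, `O=C(Nc1ccc(Oc2ccnc3[nH]ccc23)c(F)c1)c1cc2cccnc2n(-c2ccc(F)cc2)c1=O`, gives 620 nM.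

Compound 3 stands lowest of the three numbers: the step of a 2.2-fold lower number from compound 1 to compound 3 (0.34 log units; beyond the scatter) separates it from its nearest neighbour beyond the scatter, and compound 2 lies furthest away. Compound 4, `O=C(Nc1ccc(Oc2ccnc3[nH]ccc23)c(F)c1)c1cc2cccnc2n(-c2ccc(F)c(Cl)c2)c1=O`, differs from compound 3 by chloro in place of hydrogen on an aromatic carbon; cut one bond further out, this reads 4-fluorophenyl to 3-chloro-4-fluorophenyl, the new group sitting ortho to a fluoro group and meta to a large group. Going by the values given here, two measured steps bear on this change. The step of a 1.7-fold higher number from compound 1 to compound 2 (0.24 log units; within the scatter) altered a group on that 4-fluorophenyl ring and stayed within the scatter. The step of a 2.2-fold lower number from compound 1 to compound 3 (0.34 log units; beyond the scatter) added a fluoro on a different ring and gave a modest gain. Neither is a chloro added to the 4-fluorophenyl ring, so in this assay the step of a 1.2-fold lower number from compound 3 to compound 4 (0.09 log units; within the scatter) is expected to be small, probably within the scatter. Compound 4 is therefore estimated at 500 nM, with a range from 200 nM to 1400 nM.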

Compound 4, half-maximal inhibitory concentration: 5230 nM
Compound 4: middle estimate off by 10-fold (1.02 log units), on the low side; the whole stated range lies below it.
By their numbers in this assay, from the lowest: compound 3; then compounds 1 and 2 (each within the scatter of the next); then compound 4.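

In this assay the move from 4-fluorophenyl to 3-chloro-4-fluorophenyl gives an 8.4-fold higher number from compound 3 to compound 4 (0.93 log units; beyond the scatter) and so weakens the compound beyond the scatter, even though only one heavy atom enters. The earlier change on this ring, methoxy in place of fluoro in a 1.7-fold higher number from compound 1 to compound 2 (0.24 log units; within the scatter) stayed within the scatter, so that step gave no sign that this ring could be so sensitive to a change at another place on it. Nothing measured here explains the rise in the number.

The compounds shown leave open whether the loss belongs to chloro itself or would also follow methyl or an amine at this place. They also leave open whether chloro at this place would do the same without the fluoro that separates compound 3 from compound 1.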